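Swapping the aryl group on the ring amine nitrogen

This account rests on a few compounds, and the source may have more. Where it says the series, first, only, none or still open, it means among the compounds named here.

Compound 1 `CCc1nc(-c2cccc(F)c2)c(C(=O)N2CCN(c3cccc(OC)c3)CC2)o1`: in a functional assay on HL-60 cells (Homo sapiens) for inhibition, read by MTT assay, with a stated time of 72 h (on this read-out lower numbers stand for stronger inhibition and higher numbers for weaker inhibition), compound 1 gives 201 nM.
Compound 2 `Cc1nc(-c2ccccc2)c(C(=O)N2CCN(c3c(C)cccc3C)CC2)o1`: in this assay compound 2 gives 146 nM.

Compound 2 sits at one end of these two numbers, and compound 1 lies within the usual scatter of it, so the two cannot be told apart. Compound 3 `Cc1nc(-c2ccccc2)c(C(=O)N2CCN(c3cccc(C(F)(F)F)c3)CC2)o1` is not yet measured; it differs from compound 2 in one place: 3-(trifluoromethyl)phenyl in place of 2,6-dimethylphenyl on an amine nitrogen in a ring. Among the compounds with values here, no measured pair shows this change, so its size in this assay is open; the account expects a step no larger than the scatter, or at most a modest shift toward a weaker number. Compound 3 is estimated at 220 nM, with a range from 70 nM to 700 nM, meaning an expected step of a 1.5-fold higher number from compound 2 to compound 3 (0.18 log units; within the scatter).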

Compound 3, half-maximal inhibitory concentration: 153 nM
The estimate for compound 3 lay 1.4-fold (0.16 log units) above the measured number, and the stated range covers the measured number.
By their numbers in this assay, from the lowest: compounds 2, 3 and 1 (each within the scatter of the next).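

Within the data shown here, the step from the 2,6-dimethylphenyl to the 3-(trifluoromethyl)phenyl group gives the first matched comparison at this amine nitrogen: in this assay, a 1.0-fold higher number from compound 2 to compound 3 (0.02 log units; within the scatter). The two groups cannot be told apart here, although they differ in substitution and in heavy atoms. Nothing available explains this outcome. From the compounds shown here alone, it remains open whether the number would hold with a group of another kind on this nitrogen, such as an unsubstituted phenyl, a pyridine ring or a simple alkyl chain, or with a carboxylic acid on the aryl ring.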